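A larger group on the carbonyl carbon of compound 2

The source may report more compounds than this note shows. Statements on the series, on what has been measured and on what is new or still open speak of the compounds shown alone.

Of the compounds shown here, two have been measured so far in a functional assay on RKO cells (Homo sapiens) for inhibition, read by MTT assay, with a stated time of 48 h; on this read-out lower numbers stand for stronger inhibition and higher numbers for weaker inhibition. There, compound 1 `COc1ccc(N(C)c2nc(C)nc3ccccc23)cc1C(=O)OCC[Se]C#N` gives 2390 nM and compound 2 `COc1ccc(N(C)c2nc(C)nc3ccccc23)cc1C(=O)NCC[Se]C#N` gives 1170 nM, so compound 2 holds the lower of the two numbers. The next compound is compound 3 `COc1ccc(N(C)c2nc(C)nc3ccccc23)cc1C(=O)OCCCCCC[Se]C#N`, whose difference from compound 2 is a group of 10 heavy atoms (7 carbon, 1 nitrogen, 1 oxygen, 1 selenium; no ring) in place of a group of 6 heavy atoms (3 carbon, 2 nitrogen, 1 selenium; no ring), on a carbonyl carbon, and the rest of the structure stays the same.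

For the measured compounds named here, only one measured step bears on this change. That step is a 2.0-fold lower number from compound 1 to compound 2 (0.31 log units; beyond the scatter), and in it a group holding oxygen gave way to one without oxygen on the same carbonyl carbon. The group in compound 3 holds oxygen again, so part of that modest gain may be lost. Going by the values given here, no measured pair shows what the larger group does on its own, so the range has to stay wide. The expected change in this assay is a 1.7-fold higher number from compound 2 to compound 3 (0.23 log units; within the scatter), a small move towards weaker inhibition. For compound 3 the estimated value is 2000 nM, with an expected range from 600 nM to 7000 nM in this measurement.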

Compound 3, half-maximal inhibitory concentration: 1990 nM
For compound 3 the middle estimate is 1.0-fold (0.00 log units) above the measured one; the range from low to high includes it.
By their numbers in this assay, from the lowest: compounds 2, 3 and 1 (each within the scatter of the next, the first and the last beyond it).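

Keeping the ester and putting a longer chain in place of the shorter one gives a 1.2-fold lower number from compound 1 to compound 3 (0.08 log units; within the scatter) in this assay, so the two esters cannot be told apart in this read-out, and the longer chain is carried here with no readable effect. Set against the amide, the result is a 1.7-fold higher number from compound 2 to compound 3 (0.23 log units; within the scatter), which means that compound 3 cannot be ranked against compound 2 either, although compound 1 and compound 2 are separated by more than the scatter, and so the three numbers form no clean order by chain length or by linking atom. Nothing available here explains why the numbers fall as they do.

The compounds shown leave open what the longer chain does when it is joined through nitrogen, as the short chain is in compound 2. They also leave open whether a still longer chain would shift the number, and whether an amine or a carboxylic acid in place of the selenium and nitrile at the end of the chain would keep any of this activity.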